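2-Methoxy-6-methylphenyl Replaces 2,4,6-Trimethylphenyl: Expected Stability

The source may report more compounds than this note shows. Statements on the series, on what has been measured and on what is new or still open speak of the compounds shown alone.

Measured so far in an ADME assay on microsomes from liver (Rattus norvegicus) for metabolic stability, read by LC-MS, using NADPH, at 37 degrees C; on this read-out lower numbers stand for a shorter-lived compound and higher numbers for a longer-lived compound:
- compound 1 `Cc1cc(C)c(-c2nc(CN3CCC(C(=O)NCCCN4C[C@H](C)C[C@H](C)C4)CC3)c(C)o2)c(C)c1` gives > 0.5 h
- compound 2 `Cc1ccccc1-c1nc(CN2CCC(C(=O)NCCCN3[C@H](C)CCC[C@@H]3C)CC2)c(C)o1` gives > 0.5 h

In this assay compound 1 gives > 0.5 h, and this is a limit of the assay rather than a number. Compound 2 also stands at a limit in this assay, where compound 2 gives > 0.5 h. Within the data shown here, both values therefore sit at the limit of > 0.5 h in this assay, at which 2 of the 2 values shown sit, and the two compounds show only that each reached that limit; no step between them can be sized.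

Compound 3 `COc1cccc(C)c1-c1nc(CN2CCC(C(=O)NCCCN3C[C@H](C)C[C@H](C)C3)CC2)c(C)o1` differs from compound 1 in 2-methoxy-6-methylphenyl in place of 2,4,6-trimethylphenyl on an aromatic carbon. Among the measured compounds shown here, no measured step guides this change, so the step that the limit leaves unreadable from compound 1 to compound 3 is expected to be none beyond the scatter, with compound 3 most likely reported again as a limit. For compound 3 the half-life in this assay is estimated at 0.8 h, within a range from 0.35 h to 2 h.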

Compound 3, half-life: 0.0767 h
For compound 3 the middle estimate is 10-fold (1.02 log units) above the measured one; measured number below the stated range.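

Among these compounds, compound 3 is the first compound here to give a number rather than a limit in this assay: compound 3 gives 0.0767 h. This shows that the aryl group on this aromatic carbon is not a neutral place to make changes, as 2-methoxy-6-methylphenyl in place of 2,4,6-trimethylphenyl gives an at least 6.5-fold lower number from compound 1 to compound 3 (0.81 log units; beyond the scatter), a step beyond the scatter. The step has only a lower bound, since the value of compound 1 is a limit of the assay: the limit of > 0.5 h in this assay, at which 2 of the 3 values shown sit.

The compounds shown do not separate the methoxy group that enters from the methyl groups that leave, so it stays open which of these carries the step. On these data alone, it is also open whether an ethoxy group or a chlorine in place of the methoxy would give the same result.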